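The compounds below may be only part of what the source reports. "The series", "measured", "known", "first", "only" and "open" are said of these compounds alone.

Three esters built on the shared core have been measured in an ADME assay on a cell-free system (plasma, Homo sapiens) for metabolic stability, with Plasma (Rattus norvegicus) as the target, read by HPLC, at pH 7.4; a lower number here means that the compound disappears faster, a higher number that the compound lasts longer. Compound 1 `CC(=O)Oc1ccccc1C(=O)O[C@H]1CO[C@H]2[C@@H]1OC[C@H]2OC(=O)c1ccccc1O` gives 0.0825 h, compound 3 `CC(=O)Oc1ccccc1C(=O)O[C@H]1CO[C@H]2[C@@H]1OC[C@H]2OC(=O)c1cnccc1Cl` gives 0.0642 h, and compound 2 `CC(=O)Oc1ccccc1C(=O)O[C@H]1CO[C@H]2[C@@H]1OC[C@H]2OC(=O)c1ccc(O)cc1` gives 0.0198 h, the lowest of the three numbers. Compound 4 `CC(=O)Oc1ccccc1C(=O)O[C@H]1CO[C@H]2[C@@H]1OC[C@H]2OC(=O)c1cnoc1C` has not yet been measured. It differs from compound 2 in a single group on the carbonyl carbon: 5-methyl-1,2-oxazol-4-yl in place of 4-hydroxyphenyl on a carbonyl carbon Two measured steps bear on this change, since each replaces the same group at the same carbonyl carbon: a 4.2-fold lower number from compound 1 to compound 2 (0.62 log units; beyond the scatter) and a 3.2-fold higher number from compound 2 to compound 3 (0.51 log units; beyond the scatter). Compound 1 and compound 3 both stand higher than compound 2, so a modest rise beyond the scatter is expected, a 2.5-fold higher number from compound 2 to compound 4 (0.40 log units; beyond the scatter). Compound 4 is therefore estimated at 0.05 h, within a range of 0.02 h to 0.12 h.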

Compound 4, half-life: 0.193 h
Compound 4: middle estimate off by 3.9-fold (0.59 log units), on the low side; the measured number lies above the stated range.
By their numbers in this assay, from the lowest: compound 2; then compounds 3 and 1 (each within the scatter of the next); then compound 4.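

Compound 4 stands highest of the four, and each of its steps lies beyond the scatter: a 9.7-fold higher number from compound 2 to compound 4 (0.99 log units; beyond the scatter) and a 3.0-fold higher number from compound 3 to compound 4 (0.48 log units; beyond the scatter) and a 2.3-fold higher number from compound 1 to compound 4 (0.37 log units; beyond the scatter) on the same carbonyl carbon. The earlier groups therefore did not mark the upper end at this position, and 5-methyl-1,2-oxazol-4-yl, a five-membered aromatic ring with 2 hetero atoms, stands above all three. Nothing given here explains why this group gives the longest half-life.

The compounds shown leave open whether the ring or its methyl carries this rise. They also leave open how an amine, a carboxylic acid or a longer chain in place of that methyl would stand.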